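The compounds below may be only part of what the source reports. "The series", "measured", "known", "first", "only" and "open" are said of these compounds alone.

Compound 1 `Cc1cc(C)c(CN2CCc3c(Cl)cc([C@@H](CO)[C@@H]4CCOC4)c(Cl)c3C2=O)c(=O)[nH]1`: 2910 nM
Compound 2 `CCOC(c1cc(Cl)c2c(c1Cl)C(=O)N(Cc1c(C)cc(C)[nH]c1=O)CC2)C1CS(=O)(=O)C1`: 6080 nM; 62 nM (2 entries)
Compound 3 `Cc1cc(C)c(CN2CCc3c(Cl)cc(C(CO)C4CCOC4)c(Cl)c3C2=O)c(=O)[nH]1`: 1010 nM; 15 nM (2 entries)

Of the compounds shown here, three have been measured in an assay on cells for inhibition of histone-lysine N-methyltransferase EZH2 (Homo sapiens), read by ELISA, with a stated time of 72 h (a higher number here means a weaker inhibitor, a lower number a stronger inhibitor), and the picture is uneven. For the measured compounds named here, compound 1 gives 2910 nM in this assay, and that is the only number it carries; two further entries for compound 1 did not yield a single number. Compound 2 gives 6080 nM; 62 nM (2 entries), and compound 3 gives 1010 nM; 15 nM (2 entries); for both, the entries disagree with each other (the several entries of compound 2 in this assay, 6080 nM; 62 nM (2 entries), (the several entries of compound 3 in this assay, 1010 nM; 15 nM (2 entries))), so neither offers a firm anchor. Compound 1 and compound 3 differ only in that one is drawn with a defined configuration and the other without (the fact that one of compounds 1 and 3 is drawn with a defined configuration and the other without, at the place where they differ), and what their values show is a weak number for compound 1 against a spread of numbers for compound 3. Going by the values given here, no step between measured compounds can be computed here.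

Compound 4 `Cc1cc(C)c(CN2CCc3c(Cl)cc(-c4c(C)noc4C)c(Cl)c3C2=O)c(=O)[nH]1` has not been measured. It differs from compound 1 by a group of 7 heavy atoms (5 carbon, 1 nitrogen, 1 oxygen; one five-membered aromatic ring with 2 hetero atoms) in place of a group of 8 heavy atoms (6 carbon, 2 oxygen; one five-membered non-aromatic ring with 1 hetero atom), on an aromatic carbon. In this assay compound 4 is expected to be a stronger inhibitor than compound 1, with an estimated step of a 7.3-fold lower number from compound 1 to compound 4 (0.86 log units; beyond the scatter), beyond the usual scatter but uncertain in size given the disagreement within compound 3 (the several entries of compound 3 in this assay, 1010 nM; 15 nM (2 entries)). Compound 4 is thus estimated at 400 nM, within a range from 40 nM to 4000 nM.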

Compound 4, half-maximal inhibitory concentration: 17 nM
Beside the measured number, compound 4's estimate is 24-fold (1.37 log units) above it; the whole stated range lies above it.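

In this assay, replacing the group with the five-membered non-aromatic ring and two defined stereocentres by 3,5-dimethyl-1,2-oxazol-4-yl, on the aromatic carbon para to a fused ring and ortho to a chloro group, gives a 170-fold lower number from compound 1 to compound 4 (2.23 log units; beyond the scatter). For the compounds shown here, the earlier compounds carried only non-aromatic groups at this position, so compound 4 is the first to show that a five-membered aromatic ring is accepted here, and that the shared core can reach 17 nM in compound 4 with a group that has no hydrogen-bond donor and no stereocentre. The size of the step should still be read with care, as it rests on the single number for compound 1, while compound 3, which differs from compound 1 only in how its configuration is drawn, has entries that disagree widely: the several entries of compound 3 in this assay, 1010 nM; 15 nM (2 entries)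

The compounds shown leave open how much of the step belongs to the aromatic ring itself and how much to its two methyl groups. Also open, from the compounds shown here alone, is how this position would respond to a phenyl ring, a pyridine ring or a primary amine.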